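The source may hold more compounds than are shown below. What is called first, only, known or untested is meant among the compounds shown, and "the series" means these compounds.

Measured in a functional assay on HCT-116 cells (Homo sapiens) for inhibition, read by MTT assay, with a stated time of 2 days, tested at 10 uM (on this read-out higher numbers stand for more inhibition at the one concentration tested (going by the name of the read-out) and lower numbers for less inhibition), so far:
compound 1 `COc1cc(OC)cc(-c2cn(-c3ccc(O)c(C(=O)O)c3)nn2)c1` gives 2%
compound 2 `COc1cc(OC)cc(-c2cn(-c3ccc(O)c(C(=O)OCCCc4ccccc4)c3)nn2)c1` gives 19%
compound 3 `COc1ccccc1-c1cn(-c2ccc(O)c(C(=O)OCCCc3ccccc3)c2)nn1` gives 7%

Compound 2 is the only one of the three to reach a value beyond the scatter of the others. Compound 1 differs from compound 2 by hydrogen in place of 3-phenylpropyl on an oxygen next to a carbonyl group; the step is a number 17 percentage points lower from compound 2 to compound 1 (beyond the scatter). Compound 3 differs from compound 2 in the core, (2-methoxyphenyl in place of 3,5-dimethoxyphenyl on an aromatic carbon), and the step is a number 12 percentage points lower from compound 2 to compound 3 (beyond the scatter). The values of compound 1 and compound 3 lie within the scatter of each other, so no order between them is claimed.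

Compound 4 `COc1ccccc1-c1cn(-c2ccc(O)c(C(=O)O)c2)nn1` has not been measured in this assay. It differs from compound 3 by hydrogen in place of 3-phenylpropyl on an oxygen next to a carbonyl group. This is the same change as from compound 2 to compound 1, at the same place, so the series holds this change twice, once measured. Within the data shown here, the only measured instance gave a modest loss, and compound 3 starts from a lower value than compound 2 did, which leaves little room for a loss of the same size before the read-out reaches zero.

In this assay compound 4 is expected to give about 2%, within -8% to 10%. This estimate means a step of a number 5 percentage points lower from compound 3 to compound 4 (within the scatter), a smaller step than the earlier one. The expectation rests on the step of a number 17 percentage points lower from compound 2 to compound 1 (beyond the scatter) and on the low starting value of compound 3, 7%.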

Compound 4, a percentage reported as inhibition, at one concentration (the size of the read-out at that concentration, not a potency): 4%
For compound 4 the middle estimate is 2 percentage points below the measured one; measured number inside the range.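

In this assay, the change from 3-phenylpropyl to hydrogen on an oxygen next to a carbonyl group gives a number 3 percentage points lower from compound 3 to compound 4 (within the scatter), so no loss can be claimed on this core. Set beside the earlier instance of the change, this step cannot be told apart from it: the same change on two cores in this assay, a number 17 percentage points lower (beyond the scatter) from compound 2 to compound 1 and a number 3 percentage points lower (within the scatter) from compound 3 to compound 4, 14 percentage points apart, within the scatter of two such steps

The series therefore gives no ground for saying that the change behaves differently on the two cores, but it also does not show that the change carries over at the same size: compound 3 gives only 7%, which leaves little room for a drop on this read-out, and two instances on two cores make too small a set for a rule.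

The compounds shown leave open whether the value of compound 2, 19%, depends on the 3-phenylpropyl chain itself or would also be reached with a shorter or longer chain, or with an amide in place of the ester link. They also leave open how a halogen such as chlorine on the aromatic ring in place of the methoxy groups would compare, and whether the change can be read more clearly on a core with a higher starting value.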